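From 1-benzofuran-2-yl to ethynyl on the shared core

The compounds below may be only part of what the source reports. "The series", "measured", "known", "first", "only" and "open" are said of these compounds alone.

Of the compounds shown here, three with aromatic groups on the shared core have been measured in an ADME assay on BJ cells (Homo sapiens), read by MTT assay, with a stated time of 72 h; a higher number here means a weaker inhibitor, a lower number a stronger inhibitor. There, compound 1 `CNc1ncnc2c1c(-c1ccoc1)cn2[C@@H]1O[C@H](CO)[C@@H](O)[C@H]1O` gives 96300 nM. Compound 2 `CNc1ncnc2c1c(-c1cccs1)cn2[C@@H]1O[C@H](CO)[C@@H](O)[C@H]1O` reaches > 100000 nM, which is a limit of the assay and not a number. Among the measured compounds shown here, compound 3 `CNc1ncnc2c1c(-c1cc3ccccc3o1)cn2[C@@H]1O[C@H](CO)[C@@H](O)[C@H]1O` gives 75600 nM, and it stands within the scatter of the one other exact number, the step being a 1.3-fold lower number from compound 1 to compound 3 (0.11 log units; within the scatter). Compound 4 `C#Cc1cn([C@@H]2O[C@H](CO)[C@@H](O)[C@H]2O)c2ncnc(NC)c12` carries ethynyl in place of 1-benzofuran-2-yl on an aromatic carbon. For the measured compounds named here, the measured steps exchange only one aromatic group for another, so they bear on this change only loosely. Besides the step already given, they are an at least 1.0-fold higher number from compound 1 to compound 2 (0.01 log units; that floor lies within the scatter) and an at least 1.3-fold lower number from compound 2 to compound 3 (0.12 log units; that floor lies within the scatter), and neither floor leaves the scatter. Going by the values given here, no measured step shows a ring giving way to a group without one, so no shift beyond the scatter is expected, though the range stays wide. The expected step is a 1.1-fold lower number from compound 3 to compound 4 (0.03 log units; within the scatter). The estimate for compound 4 is 70000 nM, with an expected range from 15000 nM to 100000 nM.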

Compound 4, half-maximal inhibitory concentration: 86000 nM
Compound 4: middle estimate off by 1.2-fold (0.09 log units), on the low side, and the stated range covers the measured number.
By their numbers in this assay, from the lowest: compounds 3, 4 and 1 (each within the scatter of the next). At a limit, above all of these: compound 2.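

In this assay, ethynyl, which has no ring, gives a number within the scatter of that seen with the two-ring 1-benzofuran-2-yl group: a 1.1-fold higher number from compound 3 to compound 4 (0.06 log units; within the scatter). It also stays within the scatter of the number seen with furan-3-yl: a 1.1-fold lower number from compound 1 to compound 4 (0.05 log units; within the scatter). Compound 2 stands at a limit of the assay and not a number, so an at least 1.1-fold lower number from compound 2 to compound 4 (0.06 log units; that floor lies within the scatter) gives only a floor for that step: the limit of > 100000 nM in this assay, at which 1 of the 4 values shown sits.

Among the exact values, then, the loss of every ring at this aromatic carbon does not move the number beyond the scatter. The compounds shown leave open whether any other kind of group here, such as an amine, a carboxylic acid or a longer chain, would do so.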